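Ring methyl step repeated on two urea cores

This account rests on a few compounds, and the source may have more. Where it says the series, first, only, none or still open, it means among the compounds named here.

Compound 1 `Cc1cc(NNC(=O)Nc2cc(Cl)nc(Cl)c2)ncc1-c1cnn(C)c1` and compound 2 `Cc1cc(NNC(=O)Nc2cc(Cl)nc(Cl)c2)ncc1-c1cn(C)nc1C` share one core; compound 3 `Cc1cc(CNC(=O)Nc2cc(OCCO)nc(C(F)(F)F)c2)nnc1-c1cn(C)nc1C(F)(F)F` and compound 4 `Cc1cc(CNC(=O)Nc2cc(C(F)(F)F)nc(OCCO)c2C)nnc1-c1cn(C)nc1C(F)(F)F` share another, and the difference between the two cores is not broken down here. In a functional assay on CHO cells for agonist activity at sphingosine 1-phosphate receptor 2 (Homo sapiens), read by fluorescence and calcium flux, with a stated time of 3 min (on this read-out higher numbers stand for weaker inhibition and lower numbers for stronger inhibition), compound 1 gives > 23000 nM, a limit of the assay and not a number. In this assay compound 2 gives > 23000 nM, likewise a limit. The step between them, a step that the two limits leave unreadable from compound 1 to compound 2, rests on the change (methyl in place of hydrogen on an aromatic carbon). In this assay, among the compounds with values here, compound 3 gives 4000 nM, the only number here, while (the limit of > 23000 nM in this assay, at which 2 of the 3 values shown sit). The change to compound 4 is the same kind of change, (methyl in place of hydrogen on an aromatic carbon), but here the methyl sits on a six-membered aromatic ring with one nitrogen, ortho to a 2-hydroxyethoxy group and para to a trifluoromethyl group, not on a five-membered ring next to the ring nitrogen. With the measured step unreadable, the expected step is no change at the digits printed from compound 3 to compound 4 (within the scatter), roughly a standstill. Compound 4 is estimated at 4000 nM, between 1500 nM and 12000 nM.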

Compound 4, half-maximal inhibitory concentration: 4400 nM
Estimate against measurement, compound 4: 1.1-fold (0.04 log units) below; measured number inside the range.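

In this assay, methyl in place of hydrogen on the six-membered aromatic ring gives a 1.1-fold higher number from compound 3 to compound 4 (0.04 log units; within the scatter), so the two values on this core cannot be told apart. The same kind of change on the other core cannot be read, since compound 1 and compound 2 each give a limit of the assay and not a number: the limit of > 23000 nM in this assay, at which 2 of the 4 values shown sit. The methyl also sits on a different ring in compound 2 than in compound 4, so carry-over between the cores is neither shown nor ruled out.

Open, going by these compounds, is whether an amine or a carboxylic acid at the methyl's place would leave the value just as unmoved. Also open, on these data alone, is whether a longer chain in place of the 2-hydroxyethoxy group would shift it.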